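A Shorter Amine Chain on a Fluorinated Benzoxazole Core

The compounds below may be only part of what the source reports. "The series", "measured", "known", "first", "only" and "open" are said of these compounds alone.

Of the compounds shown here, three from one series have been measured in a functional assay on MCF7 cells (Homo sapiens) for cytotoxicity, read by MTT assay, with a stated time of 24 h; a higher number here means a weaker inhibitor, a lower number a stronger inhibitor. Compound 1 `Cc1cc(-c2nc3ccccc3o2)ccc1NC(=O)CN1CCN(CCN(C)C)CC1` gives 41600 nM in this assay. Compound 2 `Cc1cc(-c2nc3ccccc3o2)ccc1NC(=O)CN1CCN(CCCN(C)C)CC1` gives 11300 nM. Compound 3 `Cc1cc(-c2nc3cc(F)ccc3o2)ccc1NC(=O)CN1CCN(CCCN(C)C)CC1` gives 7770 nM, the lowest of the three numbers.

Two changes link the measured compounds. The first is dimethylamino in place of (dimethylamino)methyl on a saturated chain carbon, two bonds along the chain from an amine nitrogen in a ring, and the step it made was a 3.7-fold higher number from compound 2 to compound 1 (0.57 log units; beyond the scatter). The second separates the core of compound 2 from that of compound 3: fluoro in place of hydrogen on an aromatic carbon, a step of a 1.5-fold lower number from compound 2 to compound 3 (0.16 log units; within the scatter).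

Compound 4 `Cc1cc(-c2nc3cc(F)ccc3o2)ccc1NC(=O)CN1CCN(CCN(C)C)CC1` has not yet been measured. It differs from compound 3 by dimethylamino in place of (dimethylamino)methyl on a saturated chain carbon, two bonds along the chain from an amine nitrogen in a ring. Among the measured compounds shown here, this is the same change as the one from compound 2 to compound 1, made here on the fluorinated core shared by compound 3 and compound 4, so the change occurs twice among the four compounds.

For the measured compounds named here, only one example of this change has a measured outcome, and it was a clear weakening. The expectation is that the step from compound 3 to compound 4 will be of similar size, estimated at a 3.5-fold higher number from compound 3 to compound 4 (0.54 log units; beyond the scatter), because the same change gave a 3.7-fold higher number from compound 2 to compound 1 (0.57 log units; beyond the scatter). On that basis compound 4 is expected to give about 27000 nM in this assay, with a likely range from 12000 nM to 60000 nM.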

Compound 4, half-maximal inhibitory concentration: 10400 nM
The estimate for compound 4 lay 2.6-fold (0.41 log units) above the measured number; measured number below the stated range.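

In this assay, the change from 3-(dimethylamino)propyl to 2-(dimethylamino)ethyl gave a 1.3-fold higher number from compound 3 to compound 4 (0.13 log units; within the scatter) on the core of compound 3, so the clear weakening seen on the core of compound 2 did not carry over at the same size: the same change on two cores in this assay, a 3.7-fold higher number (0.57 log units; beyond the scatter) from compound 2 to compound 1 and a 1.3-fold higher number (0.13 log units; within the scatter) from compound 3 to compound 4, 2.8-fold (0.44 log units) apart, beyond the scatter of two such steps. Read the other way, fluoro in place of hydrogen gave a 4.0-fold lower number from compound 1 to compound 4 (0.60 log units; beyond the scatter) on the 2-(dimethylamino)ethyl chain, a larger step than the one on the 3-(dimethylamino)propyl chain: the same change on two cores in this assay, a 1.5-fold lower number (0.16 log units; within the scatter) from compound 2 to compound 3 and a 4.0-fold lower number (0.60 log units; beyond the scatter) from compound 1 to compound 4, 2.8-fold (0.44 log units) apart, beyond the scatter of two such steps. Among the compounds shown here, these four compounds therefore show that the effect of the chain change differs between the two cores and cannot simply be transferred from one to the other, but they do not show why, and with only two cores and two chains they cannot say which of the two steps would be more typical on a further core.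

The compounds shown leave open whether a longer chain than 3-(dimethylamino)propyl would follow either trend, and whether a terminal morpholine in place of dimethylamino would behave alike on both cores. They also leave open whether chloro in place of fluoro would produce the same dependence on chain length.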